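The compounds below may be only part of what the source reports. "The series", "measured", "known", "first", "only" and "open" are said of these compounds alone.

In a functional assay on HT-29 cells (Homo sapiens) for inhibition (on this read-out lower numbers stand for stronger inhibition and higher numbers for weaker inhibition), compound 3 `COc1ccc(/C=C/c2ccc3ccccc3c2)cc1N` gives > 5000 nM, which is a limit of the assay and not a number. This is the only such case among the three compounds tested: the limit of > 5000 nM in this assay, at which 1 of the 3 values shown sits. Compound 1 `COCCOc1cc(/C=C\c2ccc3ccccc3c2)ccc1OC` gives 2990 nM and compound 2 `COc1ccc(/C=C\c2ccc3ccccc3c2)cc1[N+](=O)[O-]` gives 3280 nM, and both have the double bond drawn Z.

The next comparison is with compound 4 `COc1ccc(/C=C\c2ccc3ccccc3c2)cc1N`, and the structural change is this: the two compounds have the same atoms and bonds and differ only in configuration as drawn: 1 of 1 stereo elements differ; a double bond is drawn E in compound 3 and Z in compound 4. Among the measured compounds shown here, no measured pair yet differs only at the double bond. For the measured compounds named here, the single measured step, a 1.1-fold higher number from compound 1 to compound 2 (0.04 log units; within the scatter), lies within the scatter and concerns a different place, so it bears only indirectly. It does show that the two Z compounds stay close in this assay across that substitution.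

Compound 4 shares the Z drawing and the shared core, so a reading near those of compound 1 at 2990 nM and compound 2 at 3280 nM is the working expectation. A numerical reading is expected, though another limit cannot be excluded. The expected step is an at least 2.2-fold lower number from compound 3 to compound 4 (0.35 log units; beyond the scatter), towards a lower number, and its size stays loose, as compound 3 has no number. Compound 4 is estimated at 2200 nM, with an expected range of 500 nM to 6000 nM.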

Compound 4, half-maximal inhibitory concentration: 1820 nM
Estimate against measurement, compound 4: 1.2-fold (0.08 log units) above; the measured number falls inside the stated range.
By their numbers in this assay, from the lowest: compounds 4, 1 and 2 (each within the scatter of the next). At a limit, above all of these: compound 3.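

In this assay the double bond now has its first measured pair, with a step of an at least 2.7-fold lower number from compound 3 to compound 4 (0.43 log units; beyond the scatter), and the configuration is the only change: the fact that compounds 3 and 4 differ only in the configuration as drawn

From the compounds shown here alone, compound 3 stands at > 5000 nM, which is a limit and not a number, so only the direction of the step and its lower bound can be read, and its full size stays open.

On the aromatic carbon, the substituent change shows no separation among the Z compounds, with a 1.8-fold lower number from compound 2 to compound 4 (0.26 log units; within the scatter) and a 1.6-fold lower number from compound 1 to compound 4 (0.22 log units; within the scatter), so amino, nitro and 2-methoxyethoxy cannot be told apart at this position in this assay.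

The compounds shown leave open whether the preference for the Z drawing holds with nitro or 2-methoxyethoxy on that carbon, as the only E compound among them carries amino. Also open, going by these compounds, is how a carboxylic acid, an acetamide or a longer alkoxy chain at this position would read in this assay, and whether any such group would move the number beyond the scatter of the three Z compounds.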